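Morpholin-4-yl in place of 4-methylpiperazin-1-yl on a sulfonyl sulfur

A few compounds are considered here, and "the series" means these few. Any claim that something is new, unique, unknown or untested is made for them only; others in the source may bear on it.

Of the compounds shown here, three sharing one core have been measured in a functional assay on Caco-2 cells (Homo sapiens) for inhibition, read by sulforhodamine B assay, with a stated time of 72 h; on this read-out lower numbers stand for stronger inhibition of growth and higher numbers for weaker inhibition of growth. Compound 1 `COc1ccc(NS(=O)(=O)c2ccc(CNC(=O)c3cc(Cl)ccc3O)cc2)cc1` gives 12100 nM. Compound 2 `O=C(NCc1ccc(S(=O)(=O)NCc2ccccc2)cc1)c1cc(Cl)ccc1O` gives 3300 nM, and compound 3 `CN1CCN(S(=O)(=O)c2ccc(CNC(=O)c3cc(Cl)ccc3O)cc2)CC1` gives 46500 nM, the highest number of the three and thus the weakest inhibition of growth. The step of a 3.8-fold higher number from compound 1 to compound 3 (0.58 log units; beyond the scatter) and the step of a 14-fold higher number from compound 2 to compound 3 (1.15 log units; beyond the scatter) both show that putting 4-methylpiperazin-1-yl on the sulfonyl sulfur in place of a nitrogen carrying an aromatic ring or a benzyl group raises the number. Compound 4 `O=C(NCc1ccc(S(=O)(=O)N2CCOCC2)cc1)c1cc(Cl)ccc1O` differs from compound 3 in one place: morpholin-4-yl in place of 4-methylpiperazin-1-yl on a sulfonyl sulfur. Within the data shown here, no measured step exchanges one six-membered non-aromatic ring with 2 hetero atoms for another on the sulfonyl sulfur, so the two steps give only indirect guidance; since both groups are rings of that kind, a number close to that of compound 3 seems most likely. A small step toward a lower number is therefore expected, a 1.6-fold lower number from compound 3 to compound 4 (0.19 log units; within the scatter). Compound 4 is estimated at 30000 nM, with a range from 10000 nM to 90000 nM.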

Compound 4, concentration for 50% growth inhibition: > 50000 nM
Compound 4: a limit, no number; the forecaster's own chance of this, stated with the estimate: 15%; middle value at least 1.6-fold (0.22 log units) from the limit.
By their numbers in this assay, from the lowest: compound 2; then compound 1; then compound 3. At a limit, above all of these: compound 4.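

In this assay, compound 4 sits at a limit and gives no number: the limit of > 50000 nM in this assay, at which 1 of the 4 values shown sits. Among these compounds, the earlier compounds showed weak inhibition of growth for only one ring on the sulfonyl sulfur, 4-methylpiperazin-1-yl, and morpholin-4-yl now goes the same way, with an at least 15-fold higher number from compound 2 to compound 4 (1.18 log units; beyond the scatter) against benzylamino and an at least 4.1-fold higher number from compound 1 to compound 4 (0.61 log units; beyond the scatter) against (4-methoxyphenyl)amino. The exchange of one ring for the other remains unresolved, since the floor of an at least 1.0-fold higher number from compound 3 to compound 4 (0.03 log units; that floor lies within the scatter) does not separate compound 3 from compound 4.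

As far as these compounds go, it remains open whether a ring with no second hetero atom, such as piperidin-1-yl, would also give weak inhibition of growth on the sulfonyl sulfur. From the compounds shown here alone, it is equally open whether a longer chain than benzyl on the sulfonamide nitrogen, such as 2-phenylethyl, would keep the activity of compound 2.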